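Removing One Fluorine From Compound 2

The source may report more compounds than this note shows. Statements on the series, on what has been measured and on what is new or still open speak of the compounds shown alone.

Measured so far:
Compound 1, `COc1ccc(C2C(C#N)=C(N)OC(c3c[nH]c4ccccc34)=C2C#N)cc1`: 26.4%
Compound 2, `N#CC1=C(N)OC(c2c[nH]c3ccccc23)=C(C#N)C1c1ccc(F)cc1`: 22.4%

Both compounds were tested in a functional assay, tested at 200 ug/mL; a lower number here means a weaker effect, a higher number a stronger effect of the compound at the concentration tested. Compound 2 stands lowest of the two numbers, but the gap to compound 1 lies within the scatter, so the two cannot be told apart on these data. For the measured compounds named here, the only measured step, a number 4 percentage points lower from compound 1 to compound 2 (within the scatter), exchanges one group on the same aromatic carbon and moves the read-out by no more than the scatter.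

Compound 3, `N#CC1=C(N)OC(c2c[nH]c3ccccc23)=C(C#N)C1c1ccccc1`, is not yet measured. It differs from compound 2 by hydrogen in place of fluoro on an aromatic carbon. Going by the values given here, no measured step removes this fluorine, so the expectation rests on the one step known at that position, which stayed within the scatter. Compound 3 is therefore expected to show a number 0.4 percentage points lower from compound 2 to compound 3 (within the scatter), that is, no change beyond the scatter. The estimate for compound 3 is 22%, with a range from 12% to 32%.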

Compound 3, a percentage reported as activity, at one concentration (the size of the read-out at that concentration, not a potency): 24.5%
For compound 3 the middle estimate is 2.5 percentage points below the measured one; measured number inside the range.
By their numbers in this assay, from the lowest: compounds 2, 3 and 1 (each within the scatter of the next).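

In this assay taking the fluoro group off this aromatic carbon gives a number 2.1 percentage points higher from compound 2 to compound 3 (within the scatter) and taking the methoxy group off the same carbon gives a number 1.9 percentage points lower from compound 1 to compound 3 (within the scatter) with no other change to the shared core. The earlier step only exchanged one group for another, whereas hydrogen now provides a plain reference, and on these numbers neither fluoro nor methoxy can be told apart from having no group there at all. No separate measurement bears on why the read-out stays so flat at this position.

From the compounds shown here alone, it remains open whether an amine, a carboxylic acid or a longer chain on this carbon would move the read-out beyond the scatter. The effect of changes elsewhere on the core also remains open, as does the behaviour of these compounds at other concentrations.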